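Thiosemicarbazone series on prostate cells: a nitro group added

This account rests on a few compounds, and the source may have more. Where it says the series, first, only, none or still open, it means among the compounds named here.

Measured compounds:
compound 1, `COc1ccc(/C=N/NC(=S)NC(C)(C)[C@H]2CC=C(C)CC2)cc1`: 1200 nM
compound 2, `CC1=CC[C@H](C(C)(C)NC(=S)N/N=C/c2ccccc2[N+](=O)[O-])CC1`: 6400 nM
compound 3, `CC1=CC[C@H](C(C)(C)NC(=S)N/N=C(\C)c2ccccc2)CC1`: > 100000 nM

Three thiosemicarbazones sharing the same core were tested in a functional assay on PC-3 cells (Homo sapiens) for inhibition, read by sulforhodamine B assay, with a stated time of 48 h; a higher number here means a weaker inhibitor of growth, a lower number a stronger inhibitor of growth. Compound 1 gives 1200 nM and compound 2 gives 6400 nM; these two differ from each other in more than one place, so their values are simply shown side by side. Going by the values given here, compound 3 is a different case: its value in this assay is a limit of the assay, not a number, and it is the one compound that sits at the limit of > 100000 nM in this assay, at which 1 of the 3 values shown sits.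

The unmeasured compound 4, `CC1=CC[C@H](C(C)(C)NC(=S)N/N=C(\C)c2ccc([N+](=O)[O-])cc2)CC1`, is compound 3 with one change: nitro in place of hydrogen on an aromatic carbon. Among the compounds with values here, no step between measured compounds that differ in one place is available here, so there is no measured step on which to rest a direction. Compound 4 is therefore expected to remain in the weak region of this assay, with an estimated step of an at least 1.2-fold lower number from compound 3 to compound 4 (0.09 log units; that floor lies within the scatter) that is uncertain in both size and direction. For compound 4 the estimate in this assay is 80000 nM, within a range from 20000 nM to 300000 nM.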

Compound 4, concentration for total growth inhibition: > 100000 nM
Compound 4: only a limit was reported; the forecaster's own chance of this, stated with the estimate: 55%; at least 1.2-fold (0.09 log units) between middle value and limit.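

Compound 3 and compound 4 both sit at a limit of this assay, not at a number, so no step between them can be read: the limit of > 100000 nM in this assay, at which 2 of the 4 values shown sit.

As far as these compounds go, what nitro in place of hydrogen does to growth inhibition, in size or direction, remains open.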